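Replacing the Diethylcarbamoyl Side Chain with Cyano

This account rests on a few compounds, and the source may have more. Where it says the series, first, only, none or still open, it means among the compounds named here.

In a functional assay on LoVo cells (Homo sapiens) for cytotoxicity, read by colorimetric assay and MTT assay (on this read-out lower numbers stand for stronger inhibition and higher numbers for weaker inhibition), compound 1 `COc1cccc2cc(-c3ccccc3)c(O)nc12` gives 10000 nM, compound 2 `CCOC(=O)Cn1c(=O)c(-c2ccc(OC)cc2)cc2c(OC)cc(OC)cc21` gives 10000 nM and compound 3 `CCN(CC)C(=O)Cn1c(=O)c(-c2ccc(OC)cc2)cc2c(OC)cc(OC)cc21` gives 10000 nM. Compound 3 therefore stands level with the other two, and none of the three separates from the others on these numbers.

The next structure, compound 4 `COc1ccc(-c2cc3c(OC)cc(OC)cc3n(CC#N)c2=O)cc1`, keeps the core of compound 3 and changes only the side chain: cyano in place of diethylcarbamoyl on a saturated chain carbon bound to an aromatic nitrogen.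

For the measured compounds named here, only one measured step bears on this part of the molecule. It is no change at the digits printed from compound 2 to compound 3 (within the scatter), with diethylamino in place of ethoxy on a carbonyl carbon. Going by the values given here, no measured compound carries the cyano group, so this guide is indirect, and no shift beyond the scatter is expected. The expected step is no change at the digits printed from compound 3 to compound 4 (within the scatter). For compound 4 the estimated value is 10000 nM, with an expected range from 3000 nM to 20000 nM.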

Compound 4, half-maximal inhibitory concentration: 10000 nM
The estimate for compound 4 equals the measured number at the digits printed, within the range that was stated.
By their numbers in this assay, from the lowest: compounds 1, 2, 3 and 4 (each within the scatter of the next).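

In this assay the exchange of diethylcarbamoyl for cyano reads no change at the digits printed from compound 3 to compound 4 (within the scatter) and the exchange of ethoxycarbonyl for cyano reads no change at the digits printed from compound 2 to compound 4 (within the scatter) as well. The earlier step altered only what stood on the carbonyl carbon, whereas here the carbonyl itself is gone and the seven heavy atoms of diethylcarbamoyl give way to the two of cyano, yet the printed value stays the same. No measured evidence offers an explanation for this result.

With every compound at the same printed value, the set does not show whether any group on this saturated chain carbon can shift the read-out. Going by these compounds, a carboxylic acid, a primary amine or a longer chain in this place remains open, and so does the effect of these side chains on a different core.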